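The source may report more compounds than this note shows. Statements on the series, on what has been measured and on what is new or still open speak of the compounds shown alone.

In an assay on SH-EP1 cells for agonist activity at Neuronal acetylcholine receptor; alpha4/beta2 (Homo sapiens), read by FLIPR and calcium flux (on this read-out lower numbers stand for smaller maximal responses and higher numbers for larger maximal responses), three compounds sharing one core have been measured. Compound 1 `O=C(C1CC=CC1)N1CC2CC(C1)N2` gives 95% in this assay. Compound 2 `O=C(CC1C=CCC1)N1CC2CC(C1)N2` gives 94% in this assay. Compound 3 `O=C([C@H]1C[C@H]1F)N1CC2CC(C1)N2` gives 110% in this assay, the highest of the three numbers; the nearest to it is compound 1, whose lower number lies beyond the scatter, and the furthest is compound 2, whose lower number also lies beyond the scatter.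

Compound 4 `C[C@H]1C[C@H]1C(=O)N1CC2CC(C1)N2` is the next compound to be measured in this assay. It differs from compound 3 in one place: 2-methylcyclopropyl in place of 2-fluorocyclopropyl on a carbonyl carbon. The change sits on a carbonyl carbon whose other neighbours are an amide-type nitrogen in a ring.

Among the compounds with values here, no measured pair in this set shows a 2-methylcyclopropyl against a 2-fluorocyclopropyl, so there is no step to lean on. The step of a number 10 percentage points lower from compound 3 to compound 4 (within the scatter) is expected to be small, somewhat downward, and not clearly beyond the scatter. Compound 4 is therefore expected to give 100% in this assay, with a range from 85% to 115%.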

Compound 4, largest response reached (Emax), in percent of the reference or control that the assay uses: 93%
For compound 4 the middle estimate is 7 percentage points above the measured one; the measured number falls inside the stated range.
By their numbers in this assay, from the lowest: compounds 4, 2 and 1 (each within the scatter of the next); then compound 3.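

In this assay, within the data shown here, the change from 2-fluorocyclopropyl to 2-methylcyclopropyl on a carbonyl carbon gives the first one-place comparison in this set, with a number 17 percentage points lower from compound 3 to compound 4 (beyond the scatter) as its step. It shows that the maximal response at this position depends on the substituent on the cyclopropyl ring: the two groups have the same count of heavy atoms, the same three-membered carbon ring and two defined stereocentres each, yet their values are separated by more than the scatter. No measured information on either group is available to explain this step.

On these data alone, whether an unsubstituted cyclopropyl or a 2-chlorocyclopropyl would fall nearer compound 3 or compound 4 remains open. So does whether the step would persist with the opposite stereochemistry on the cyclopropyl ring.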